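Defluorination of a quinazoline-furfurylamine series in HCT-116 cells

The source may report more compounds than this note shows. Statements on the series, on what has been measured and on what is new or still open speak of the compounds shown alone.

Measured compounds:
compound 1 `CCCCNc1nc(NCc2ccco2)c2ccccc2n1` 5470 nM
compound 2 `Fc1ccc2nc(NCCCCN3CCN(c4cccc(Cl)c4Cl)CC3)nc(NCc3ccco3)c2c1` 520 nM
compound 3 `CCCCNc1nc(NCc2ccco2)c2cc(F)ccc2n1` 4310 nM

In a functional assay on HCT-116 cells (Homo sapiens) for cytotoxicity, read by MTT assay, with a stated time of 2 days (on this read-out higher numbers stand for weaker inhibition and lower numbers for stronger inhibition), compound 2 gives 520 nM, the lowest of the three numbers; compound 3 gives 4310 nM and compound 1 gives 5470 nM. The step of a 1.3-fold higher number from compound 3 to compound 1 (0.10 log units; within the scatter) comes from the change (hydrogen in place of fluoro on an aromatic carbon). The difference between the cores of compound 2 and compound 3 is not broken down here. Compound 4 `Clc1cccc(N2CCN(CCCCNc3nc(NCc4ccco4)c4ccccc4n3)CC2)c1Cl` is not yet measured. It differs from compound 2 by hydrogen in place of fluoro on an aromatic carbon, the same change as from compound 3 to compound 1, at a place described in the same words. Because a 1.3-fold higher number from compound 3 to compound 1 (0.10 log units; within the scatter) lies within the scatter, a similarly small step is expected for compound 4 in this assay, namely a 1.3-fold higher number from compound 2 to compound 4 (0.12 log units; within the scatter). Compound 4 is therefore estimated at 680 nM, between 300 nM and 1500 nM.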

Compound 4, half-maximal inhibitory concentration: 3200 nM
Beside the measured number, compound 4's estimate is 4.7-fold (0.67 log units) below it, and the stated range ends below it.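

In this assay, hydrogen in place of fluoro gives a 6.2-fold higher number from compound 2 to compound 4 (0.79 log units; beyond the scatter), and this step does not match the one seen on the other core: the same change on two cores in this assay, a 1.3-fold higher number (0.10 log units; within the scatter) from compound 3 to compound 1 and a 6.2-fold higher number (0.79 log units; beyond the scatter) from compound 2 to compound 4, 4.8-fold (0.69 log units) apart, beyond the scatter of two such steps. The size of this change therefore did not carry from one core to the other, as the fluoro counts for little on the core of compound 1 but for clearly more on the core of compound 2. Going by these compounds alone, with only two pairs, this does not show what sets the difference between the cores, and it gives no rule for other cores.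

The compounds shown leave open whether a chloro or methoxy group at that aromatic carbon would act like fluoro on either core. They also leave open whether the step would stay as large with a longer chain on the core of compound 2.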